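Inverting one stereocentre: compound 2 to compound 3

The compounds below may be only part of what the source reports. "The series", "measured", "known", "first", "only" and "open" are said of these compounds alone.

In a functional assay on Vero cells (Chlorocebus sabaeus) for inhibition (a lower number here means a stronger inhibitor, a higher number a weaker inhibitor), compound 2 (`Nc1nc(Cl)c2ncn([C@H]3CS[C@@H](CO)O3)c2n1`) reads > 100000 nM as a limit of the assay, not a number. For the measured compounds named here, compound 1 (`Nc1nc(O)c2ncn([C@@H]3CS[C@@H](CO)O3)c2n1`) gives 63600 nM as the only numeric reading so far. Compound 3 (`Nc1nc(Cl)c2ncn([C@@H]3CS[C@@H](CO)O3)c2n1`) keeps the atoms and bonds of compound 2 and differs only in configuration as drawn (the two compounds have the same atoms and bonds and differ only in configuration as drawn: 1 of 2 stereo elements differ; a stereocentre at a saturated ring carbon is drawn R in compound 2 and S in compound 3). Going by the values given here, no measured step is available to size this change, so compound 1 at 63600 nM is the only guide. The expected move (an at least 1.4-fold lower number from compound 2 to compound 3 (0.15 log units; that floor lies within the scatter)) is small, towards stronger inhibition, and possibly none beyond the scatter. For compound 3 the estimated value is 70000 nM (expected range 25000 nM to 100000 nM).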

Compound 3, half-maximal inhibitory concentration: > 100000 nM
Compound 3: no number, only a limit (the forecaster's own chance of this, stated with the estimate: 50%); at least 1.4-fold (0.15 log units) between middle value and limit.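

In this assay compound 3 gives > 100000 nM, a limit of the assay and not a number. The effect of inverting the stereocentre at the saturated ring carbon therefore cannot be read, and with chloro neither configuration gives a numeric reading: the limit of > 100000 nM in this assay, at which 2 of the 3 values shown sit. The swap of chloro in place of hydroxy on an aromatic carbon gives an at least 1.5-fold higher number from compound 1 to compound 3 (0.19 log units; that floor lies within the scatter), so this change shows no gain in inhibition.

On these data alone, the size of the stereochemical effect remains open, as does the effect of the same inversion with hydroxy. Also open, as far as these compounds go, is how an amine or a methoxy group would read in place of chloro.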